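This account rests on a few compounds, and the source may have more. Where it says the series, first, only, none or still open, it means among the compounds named here.

Among the compounds with values here, in an ADME assay on S9 fraction from liver (Rattus norvegicus, strain Wistar) for metabolic stability, tested at 0.1 uM (on this read-out lower numbers stand for slow clearance and higher numbers for fast clearance), compound 1 `Cn1c(N2CCCC2)cc(OCc2cc(F)c(Oc3ccc(Cl)c(C(F)(F)F)c3)c(F)c2)nc1=O` gives 3.11 mL/min/kg, while compound 2 `Cn1c(N2CCC(F)(F)CC2)cc(OCc2cc(F)c(Oc3ccc(Cl)c(C(F)(F)F)c3)c(F)c2)nc1=O` gives 23.6 mL/min/kg, the higher of the two numbers measured so far. The unmeasured compound 3 `Cn1c(N2CCN(C3CC3)CC2)cc(OCc2cc(F)c(Oc3ccc(Cl)c(C(F)(F)F)c3)c(F)c2)nc1=O` keeps the shared core and differs from compound 2 at a single place: 4-cyclopropylpiperazin-1-yl in place of 4,4-difluoropiperidin-1-yl on an aromatic carbon. Within the data shown here, only one measured step bears on this place. Putting 4,4-difluoropiperidin-1-yl in place of pyrrolidin-1-yl gave a 7.6-fold higher number from compound 1 to compound 2 (0.88 log units; beyond the scatter), a modest step beyond the scatter. This shows that a change here can move the number, but that step involves neither a piperazine nor a cyclopropyl group, so it sets no firm direction for the new change. Only a small drop, not clearly beyond the scatter, is therefore expected, and the expected step is a 2.0-fold lower number from compound 2 to compound 3 (0.29 log units; within the scatter). For compound 3, the estimated clearance is 12 mL/min/kg, with an expected range of 3.5 mL/min/kg to 40 mL/min/kg.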

Compound 3, clearance: 13.7 mL/min/kg
For compound 3 the middle estimate is 1.1-fold (0.06 log units) below the measured one; the range from low to high includes it.
By their numbers in this assay, from the lowest: compound 1; then compounds 3 and 2 (each within the scatter of the next).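

In this assay, 4-cyclopropylpiperazin-1-yl in place of 4,4-difluoropiperidin-1-yl gives a 1.7-fold lower number from compound 2 to compound 3 (0.24 log units; within the scatter), so these two groups cannot be told apart at this position, even though one carries fluorine and the other an extra nitrogen and a cyclopropyl ring. Set against the pyrrolidin-1-yl group, the same new group gives a 4.4-fold higher number from compound 1 to compound 3 (0.64 log units; beyond the scatter), which shows that a clear gap from compound 1 does not require the two fluorines. Nothing available explains why these groups give these numbers.

Going by these compounds, it remains open whether the low number of compound 1 belongs to pyrrolidine alone or would also appear with a smaller azetidine ring or an open-chain dimethylamino group. A morpholine ring, or a methyl group in place of the cyclopropyl on the piperazine, could also help separate the effect of each part of the new group.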